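Dropping a Methyl from a Weak Allosteric Modulator

The source may hold more compounds than are shown below. What is called first, only, known or untested is meant among the compounds shown, and "the series" means these compounds.

Two compounds were measured in an assay on HEK293 cells for positive allosteric modulation of metabotropic glutamate receptor 3 (Rattus norvegicus), read by thallium flux, with a stated time of 2.5 min; a higher number here means that more compound is needed for the effect, a lower number that less compound is needed. Compound 1 `Cc1c(OCCCCOc2cccc(C(=O)O)c2)ccc(C(=O)CC2CCCC2)c1O` pairs a cyclopentylmethyl ketone with a carboxyphenyl ether, and in this assay compound 1 gives 3400 nM. Compound 2 `Cc1ccc(C(=O)O)cc1OCCCCOc1ccc(C(=O)CC(C)C)c(O)c1C` carries an isobutyl ketone and an extra methyl on the acid-bearing ring. For compound 2 this assay reports only a limit, > 10000 nM, and not a number (the limit of > 10000 nM in this assay, at which 1 of the 2 values shown sits). Compound 3 `Cc1c(OCCCCOc2cccc(C(=O)O)c2)ccc(C(=O)CC(C)C)c1O` has not yet been measured. It differs from compound 2 in a single place: hydrogen in place of methyl on an aromatic carbon, in words hydrogen in place of methyl on an aromatic carbon. Among the measured compounds shown here, no two measured compounds differ in just one spot, so no measured step sizes this kind of change. For the measured compounds named here, the one firm number nearby belongs to the compound that shares the unmethylated acid ring with compound 3, namely compound 1 at 3400 nM. The step of an at least 1.6-fold lower number from compound 2 to compound 3 (0.22 log units; that floor lies within the scatter) is expected to be a modest gain, not far beyond the scatter. For compound 3 the expected value is 6000 nM, with a range from 2000 nM to 20000 nM.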

Compound 3, half-maximal effective concentration: 1430 nM
Beside the measured number, compound 3's estimate is 4.2-fold (0.62 log units) above it; the whole stated range lies above it.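

In this assay, the change from 5-carboxy-2-methylphenyl to 3-carboxyphenyl gives an at least 6.9-fold lower number from compound 2 to compound 3 (0.84 log units; beyond the scatter), so a single methyl on this aromatic carbon, ortho to a large group and para to the carboxy group, separates a compound with a measurable number from one without. That step is only a lower bound on the true size of the change, as compound 2 has a limit and not a number: the limit of > 10000 nM in this assay, at which 1 of the 3 values shown sits.

The second step shows that the ketone end of the molecule also moves the number, though by a smaller measured amount: with the unmethylated acid ring held constant, isopropyl in place of cyclopentyl gives a 2.4-fold lower number from compound 1 to compound 3 (0.38 log units; beyond the scatter).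

The compounds shown do not tell whether the effect at this aromatic carbon is specific to methyl, or whether a fluorine, a chlorine or a methoxy group there would behave the same way. They also leave open how large the effect of the same methyl would be with the cyclopentyl ketone of compound 1 in place of the isopropyl end of compound 3.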